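The source may report more compounds than this note shows. Statements on the series, on what has been measured and on what is new or still open speak of the compounds shown alone.

Measured so far in a functional assay on MDA-MB-231 cells (Homo sapiens) for antiproliferative activity, read by MTT assay, with a stated time of 24 h; on this read-out higher numbers stand for weaker inhibition and lower numbers for stronger inhibition:
compound 1, `COc1ccc(-c2cc(C(=O)/C=C/c3ccccc3)nc3cc(-c4ccccc4)nn23)cc1OC`: 23300 nM
compound 2, `COc1ccc(/C=C/C(=O)c2cc(-c3cc(OC)c(OC)c(OC)c3)n3nc(-c4ccccc4)cc3n2)cc1OC`: 14200 nM
compound 3, `COc1ccc(-c2cc(/C=C/C(=O)c3ccccc3)nc3cc(-c4ccccc4)nn23)cc1`: 9900 nM

On these three numbers compound 1 stands highest. Its nearest neighbour is compound 2, whose number lies within the scatter of that of compound 1, so no order between the two can be read. Compound 3 sits furthest away, and its gap from compound 1 is beyond the scatter, so compound 3 inhibits more strongly than compound 1. Compound 3 differs from compound 1 in more than one place, so what each of those changes contributes cannot be separated.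

Compound 4, `COc1ccc(-c2cc(/C=C/C(=O)c3ccc(Cl)cc3)nc3cc(-c4ccccc4)nn23)cc1OC`, is not yet measured. It differs from compound 1 in one place: 2-((4-chlorophenyl)carbonyl)ethenyl in place of (2-phenylethenyl)carbonyl on an aromatic carbon. In compound 3 the same arrangement of carbonyl and ethenyl as in compound 4 goes with the lowest of the three numbers, though compound 3 also carries a different group elsewhere and no chlorine, so it is only a loose pointer. Going by the values given here, no single-change step is available, and the expectation rests on that comparison alone. The step expected in this assay is a 2.1-fold lower number from compound 1 to compound 4 (0.33 log units; beyond the scatter), a move toward a lower number, at the edge of the scatter rather than clearly beyond it. Compound 4 is estimated at 11000 nM, with a range from 5000 nM to 25000 nM.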

Compound 4, half-maximal inhibitory concentration: 17100 nM
Compound 4: the middle estimate sits 1.6-fold (0.19 log units) below what was measured; the range from low to high includes it.
By their numbers in this assay, from the lowest: compounds 3, 2, 4 and 1 (each within the scatter of the next, the first and the last beyond it).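

In this assay, going by these compounds alone, the step at this aromatic carbon is the first single-place comparison: a 1.4-fold lower number from compound 1 to compound 4 (0.13 log units; within the scatter), so no order between the two compounds can be read. Replacing (2-phenylethenyl)carbonyl with 2-((4-chlorophenyl)carbonyl)ethenyl therefore exchanges the arrangement of carbonyl and ethenyl and brings in a chlorine without giving a readable difference on the core of compound 1, and the result offers no sign that this position responds to this particular change. Nothing available bears on why the step is this small.

The shown compounds do not separate the two parts of the change, so it remains open whether each part has little effect alone or whether they offset each other, and 2-(phenylcarbonyl)ethenyl on the same core would be the missing link between compound 1 and compound 4. Also open, going by these compounds, is whether this position tolerates other substitution more broadly, for instance a dimethylamino group or a carboxylic acid in place of the chlorine on the 2-((4-chlorophenyl)carbonyl)ethenyl group.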